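This account rests on a few compounds, and the source may have more. Where it says the series, first, only, none or still open, it means among the compounds named here.

Values in a functional assay on NCI-H2122 cells (Homo sapiens) for inhibition, read by microscopy, with a stated time of 10 days; on this read-out lower numbers stand for stronger inhibition and higher numbers for weaker inhibition:
- compound 1 `Cc1nn(C)c2c1C(c1ccccc1)C(C#N)=C(N)O2`: 9100 nM
- compound 2 `Cn1nc(-c2ccccc2)c2c1OC(N)=C(C#N)C2c1ccccc1`: > 10000 nM, a limit
- compound 3 `COc1ccc(-c2nn(C)c3c2C(c2ccccc2)C(C#N)=C(N)O3)cc1OC`: > 10000 nM, a limit

Within the data shown here, compound 1 holds the only numerical value, 9100 nM. The remaining results reach (the limit of > 10000 nM in this assay, at which 2 of the 3 values shown sit). Compound 4 `Cc1nn(C)c2c1C(c1ccc(C#N)cc1)C(C#N)=C(N)O2` is compound 1 with one structural change: cyano in place of hydrogen on an aromatic carbon. In words, this is cyano in place of hydrogen on an aromatic carbon. Among the measured compounds shown here, the only measured step, an at least 1.0-fold higher number from compound 1 to compound 2 (0.04 log units; that floor lies within the scatter), changes a different group and rests on a limit, so it gives little guidance here. No step beyond the scatter is therefore expected in this assay. The expected result is a 1.1-fold lower number from compound 1 to compound 4 (0.06 log units; within the scatter). Compound 4 is estimated at 8000 nM, with an expected range of 2500 nM to 20000 nM.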

Compound 4, half-maximal inhibitory concentration: 5600 nM
Compound 4: the middle estimate sits 1.4-fold (0.15 log units) above what was measured, and the stated range covers the measured number.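

In this assay, cyano on an aromatic carbon, para to a large group, is the only change shown at this position, and it gives a 1.6-fold lower number from compound 1 to compound 4 (0.21 log units; within the scatter). The position therefore accepts cyano without a step beyond the scatter. Compound 4 also keeps a numerical value, as compound 1 does, whereas compound 2 and compound 3 give only limits: the limit of > 10000 nM in this assay, at which 2 of the 4 values shown sit.

As far as these compounds go, whether an amine or a carboxylic acid at this position would give a step beyond the scatter stays open. Also open, from the compounds shown here alone, is whether any compound reaches a number well clear of the limit.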